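Trading phenyl for trifluoromethyl in compound 2

The compounds below may be only part of what the source reports. "The series", "measured", "known", "first", "only" and "open" are said of these compounds alone.

In a functional assay on SN12C cells (Homo sapiens) for inhibition, read by sulforhodamine B assay, with a stated time of 48 h, tested at 10 uM (on this read-out higher numbers stand for more inhibition of growth at the one concentration tested and lower numbers for less inhibition of growth), compound 2 (`CC(=O)c1cccc(Nc2ccnc(SCC(=O)c3ccc(-c4ccccc4)cc3)n2)c1`) stands at 13% and compound 3 (`CC(=O)c1ccc(Nc2ccnc(SCC(=O)c3ccc(-c4ccccc4)cc3)n2)cc1`) at 11% so the two cannot be told apart. Compound 1 (`CCOC(=O)c1ccc(Nc2ccnc(SCC(=O)c3ccc(C#N)cc3)n2)cc1`) stands at 26% and its gap to compound 2 lies beyond the scatter.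

Compound 4 (`CC(=O)c1cccc(Nc2ccnc(SCC(=O)c3ccc(C(F)(F)F)cc3)n2)c1`) carries trifluoromethyl in place of phenyl on an aromatic carbon and is otherwise the same as compound 2. For the measured compounds named here, the one measured step (a number 2 percentage points lower from compound 2 to compound 3 (within the scatter)) swaps 3-acetylphenyl for 4-acetylphenyl, a change in another place, so it offers no direct guide to this swap. A weak hint is the higher number of compound 1 (26%), which has a nitrile where compound 2 has phenyl but also differs in a second place. A modest rise is therefore expected in this assay and the estimated size is a number 5 percentage points higher from compound 2 to compound 4 (within the scatter) with little certainty. For compound 4 the expected value is 18% with an estimated range from 5% to 35% on this measure.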

Compound 4, percent growth inhibition at one concentration: 17%
Beside the measured number, compound 4's estimate is 1 percentage points above it; the range from low to high includes it.
By their numbers in this assay, from the lowest: compounds 3, 2, 4 and 1 (each within the scatter of the next, the first and the last beyond it).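

At this position, on an aromatic carbon para to a large group, trifluoromethyl in place of phenyl gives, in this assay, a number 4 percentage points higher from compound 2 to compound 4 (within the scatter), so compound 2 and compound 4 cannot be told apart. Unlike the earlier comparison with compound 1, which differs in two places, this pair changes this one place alone. In this pair, the six-membered aromatic ring can therefore give way to a group without a ring and with fewer heavy atoms, and the read-out shows no change beyond the scatter. No measurement shown here explains this result.

From the compounds shown here alone, compound 1 carries a nitrile at this position but also differs in a second place, so the effect of the nitrile alone remains open. Also open, going by these compounds, is how an amine, a carboxylic acid or a longer chain such as hexyl would compare here, and whether the swap would give a similar step alongside the 4-acetylphenyl group of compound 3.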